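The source may report more compounds than this note shows. Statements on the series, on what has been measured and on what is new or still open speak of the compounds shown alone.

Measured compounds:
compound 1 `Cc1cc(C)c(NC(=O)N(Cc2ccc(N3CCN(C)CC3)cc2)C2CCCCCC2)c(C)c1` — 57 nM
compound 2 `CN(C)c1ccc(CN(Cc2cccc(-c3cc[nH]n3)c2)C(=O)Nc2c(F)cc(F)cc2F)cc1` — 12 nM

Both compounds were tested in an assay on microsomes from intestine for inhibition of acyl-CoA:cholesterol acyltransferase (Oryctolagus cuniculus); on this read-out lower numbers stand for stronger inhibition and higher numbers for weaker inhibition. Compound 1 gives 57 nM, the higher of the two numbers recorded. Compound 2 gives 12 nM, and the gap between these two values lies beyond the usual scatter of repeated measurements, so compound 2 is the more potent of the pair.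

Compound 3 `Cc1cc(C)c(NC(=O)N(Cc2ccc(-n3cncn3)cc2)C2CCCCCC2)c(C)c1` has not yet been measured in this assay. It differs from compound 1 in a single place: 1H-1,2,4-triazol-1-yl in place of 4-methylpiperazin-1-yl on an aromatic carbon. Within the data shown here, no pair of measured compounds shares this change, so the data give no direct guide to its effect. Without such a guide, the step from compound 1 to compound 3 is expected to be a 1.2-fold higher number from compound 1 to compound 3 (0.09 log units; within the scatter), which is to say no shift beyond the scatter. Compound 3 is accordingly estimated at 70 nM, with a range from 25 nM to 200 nM.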

Compound 3, half-maximal inhibitory concentration: 26 nM
Compound 3: middle estimate off by 2.7-fold (0.43 log units), on the high side; measured number inside the range.
By their numbers in this assay, from the lowest: compound 2; then compound 3; then compound 1.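

At the position on an aromatic carbon para to a large group, 1H-1,2,4-triazol-1-yl in place of 4-methylpiperazin-1-yl gives a 2.2-fold lower number from compound 1 to compound 3 (0.34 log units; beyond the scatter) in this assay, the first direct reading of any single change among these compounds. The position therefore does not depend on the six-membered non-aromatic ring of compound 1: a five-membered aromatic ring with three hetero atoms takes its place and inhibition grows modestly. No accompanying measurement accounts for this step.

The compounds shown leave open whether the gain belongs to the 1H-1,2,4-triazol-1-yl group itself or would also appear with another ring here, such as imidazol-1-yl, pyrazol-1-yl or morpholin-4-yl. They also leave open how a plain phenyl ring or an open-chain amine such as dimethylamino would compare at this position.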